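The compounds below may be only part of what the source reports. "The series", "measured", "known", "first", "only" and "open" are said of these compounds alone.

In a physicochemical assay for solubility, read by HPLC, in phosphate buffer, measured as kinetic solubility, with a stated time of 2 h, at pH 7.4 (on this read-out higher numbers stand for higher solubility and lower numbers for lower solubility), compound 1 `CC(C)(C)n1nnnc1C(NCCNc1ccnc2cc(Cl)ccc12)c1ccc(Cl)c(Cl)c1` gives 25000 nM and compound 2 `Clc1ccc2c(NCCNC(c3ccc(Cl)c(Cl)c3)c3nnn[nH]3)ccnc2c1` gives 70100 nM, the higher of the two numbers. Compound 3 `Clc1ccc(C(NCCNc2ccnc3cc(Cl)ccc23)c2nnn[nH]2)cc1` differs from compound 2 by one change: hydrogen in place of chloro on an aromatic carbon. In words, this is hydrogen in place of chloro on an aromatic carbon. For the measured compounds named here, the only measured step, a 2.8-fold higher number from compound 1 to compound 2 (0.45 log units; beyond the scatter), is a different change, made on an aromatic nitrogen, so it is a loose guide, though there too hydrogen came in and the number rose. Only a small upward step, perhaps not beyond the scatter, is therefore expected, an estimated 1.7-fold higher number from compound 2 to compound 3 (0.23 log units; within the scatter). The expected value for compound 3 is 120000 nM, within a range of 55000 nM to 250000 nM.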

Compound 3, solubility: 164000 nM
Compound 3: the middle estimate sits 1.4-fold (0.14 log units) below what was measured, and the stated range covers the measured number.
By their numbers in this assay, from the lowest: compound 1; then compound 2; then compound 3.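

Trading 3,4-dichlorophenyl for 4-chlorophenyl gives a 2.3-fold higher number from compound 2 to compound 3 (0.37 log units; beyond the scatter) in this assay and shows that this aromatic carbon, unchanged between the earlier compounds, also affects the read-out. The earlier change on an aromatic nitrogen, a 2.8-fold higher number from compound 1 to compound 2 (0.45 log units; beyond the scatter), also brought in hydrogen and moved the number in the same direction, so two different replacements by hydrogen now agree. Nothing measured here explains why the number rises. Still open, from the compounds shown here alone, is how an amine or a carboxylic acid would compare with chloro on this aromatic carbon. The outcome of also replacing the remaining chloro with hydrogen is open too.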